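The source may report more compounds than this note shows. Statements on the series, on what has been measured and on what is new or still open speak of the compounds shown alone.

The series shares one core, carried by compound 1 `Cc1cccc(NC(=O)Nc2cccc(CNc3nccnc3Cl)c2)c1`, compound 2 `O=C(Nc1cccc(CNc2nccnc2Cl)c1)Nc1cccc(C(F)(F)F)c1` and compound 3 `CC(C)(C)c1ccc(NC(=O)Nc2cccc(CNc3nccnc3Cl)c2)cc1`. In a functional assay on MGC-803 cells (Homo sapiens) for antiproliferative activity, read by MTT assay, with a stated time of 48 h (on this read-out lower numbers stand for stronger inhibition and higher numbers for weaker inhibition), compound 1 gives 14600 nM, compound 2 gives 7290 nM and compound 3 gives 4820 nM. Compound 1 therefore stands with the highest number of the three: its nearest neighbour is compound 2, whose value lies within the scatter of its own, and its furthest is compound 3, whose value lies beyond the scatter. For the measured compounds named here, the one measured step that changes a single place runs a 2.0-fold lower number from compound 1 to compound 2 (0.30 log units; within the scatter).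

Compound 4 `Cc1ccc(NC(=O)Nc2cccc(CNc3nccnc3Cl)c2)cc1Cl` has not yet been measured in this assay. Its change from compound 1 is 3-chloro-4-methylphenyl in place of 3-methylphenyl on an amide-type nitrogen. The measured step from compound 1 to compound 2 bears on this only indirectly: it shows that another group in place of methyl on the same ring gave a number no further away than the scatter allows. Compound 3 also sits lower than compound 1, but the two differ in more than one place, so only their two values can be compared. On this basis a small downward step, or none beyond the scatter, is expected, and the step expected for compound 4 is a 1.8-fold lower number from compound 1 to compound 4 (0.26 log units; within the scatter). Compound 4 is expected to give 8000 nM, with a range from 3500 nM to 20000 nM.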

Compound 4, half-maximal inhibitory concentration: 17500 nM
Compound 4: the middle estimate sits 2.2-fold (0.34 log units) below what was measured; low and high end bracket the measured number.
By their numbers in this assay, from the lowest: compounds 3, 2, 1 and 4 (each within the scatter of the next, the first and the last beyond it).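

In this assay, 3-chloro-4-methylphenyl in place of 3-methylphenyl on the amide-type nitrogen gives a 1.2-fold higher number from compound 1 to compound 4 (0.08 log units; within the scatter), so the values of these two compounds cannot be told apart. This is a second single-place change to the group on this nitrogen, and here the entering group carries a chlorine that the leaving group lacks; like a 2.0-fold lower number from compound 1 to compound 2 (0.30 log units; within the scatter), it stays within the scatter, so neither change separates its product from compound 1, while compound 3 differs from compound 1 in more than one place and does not bear on this reading. Nothing at hand explains why the value holds across this change.

The change from compound 1 to compound 4 alters the ring in two ways at once, and the compounds shown do not separate the contribution of the chlorine from that of the moved methyl, as 3-chlorophenyl or 4-methylphenyl on the same nitrogen could. They also leave open whether a group of another kind on this ring, such as an amine or a carboxylic acid, would carry the number beyond the scatter in either direction.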